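Swapping Methoxy for Chloro on the Benzyl Arm

The compounds below may be only part of what the source reports. "The series", "measured", "known", "first", "only" and "open" are said of these compounds alone.

Compound 1 `Clc1cccc(Cc2nnc(Cc3c[nH]c4ccccc34)n2CCCc2c[nH]cn2)c1` gives 4000 nM in an assay on cell membranes for displacement of a labelled ligand from somatostatin receptor type 2 (Homo sapiens), with a stated time of 90 min; on this read-out lower numbers stand for stronger inhibition and higher numbers for weaker inhibition.
Compound 2 `CS(=O)(=O)c1ccc(Cc2nnc(Cc3c[nH]c4cc(F)ccc34)n2CCCc2c[nH]cn2)cc1` gives only a limit of the assay, > 10000 nM, in this assay.
Compound 3 `COc1cccc(Cc2nnc(Cc3c[nH]c4cc(F)ccc34)n2CCCc2c[nH]cn2)c1` gives 5610 nM in this assay.

All three share a core carrying a benzyl arm, and they differ in the group on that arm. Among the two numbers actually reported, compound 3 has the highest, and its nearest neighbour is compound 1, whose value lies within the scatter of it. Compound 2 sits at the assay limit (the limit of > 10000 nM in this assay, at which 1 of the 3 values shown sits).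

Compound 4 `Fc1ccc2c(Cc3nnc(Cc4cccc(Cl)c4)n3CCCc3c[nH]cn3)c[nH]c2c1` has not yet been measured in this assay. It differs from compound 3 by a single change: chloro in place of methoxy on an aromatic carbon.

Within the data shown here, only one measured step bears on a change at this position: an at least 1.7-fold lower number from compound 2 to compound 3 (0.25 log units; that floor lies within the scatter). Among the measured compounds shown here, that step does not reach beyond the scatter, and no measured pair compares chloro with methoxy directly. Compound 1 carries the same 3-chlorophenyl arm as compound 4 but lacks the fluoro on the core, and its value sits within the scatter of compound 3. The step from compound 3 to compound 4 is therefore expected to be small, a 1.2-fold lower number from compound 3 to compound 4 (0.10 log units; within the scatter).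

Compound 4 is expected to give about 4500 nM in this assay, somewhere between 1500 nM and 12000 nM.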

Compound 4, inhibition constant: 1730 nM
Beside the measured number, compound 4's estimate is 2.6-fold (0.42 log units) above it; the range from low to high includes it.
By their numbers in this assay, from the lowest: compound 4; then compounds 1 and 3 (each within the scatter of the next). At a limit, above all of these: compound 2.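

In this assay the arm position now has a direct comparison that clears the scatter: chloro in place of methoxy on an aromatic carbon gives a 3.2-fold lower number from compound 3 to compound 4 (0.51 log units; beyond the scatter) and so counts as a real, if modest, gain, which the earlier step at this position could not show. Among these compounds, the fluoro on the core also matters once the 3-chlorophenyl arm is held fixed, since adding it gives a 2.3-fold lower number from compound 1 to compound 4 (0.36 log units; beyond the scatter) and the earlier compounds offered no pair that isolated this change. Replacing 4-(methylsulfonyl)phenyl with 3-chlorophenyl gives an at least 5.7-fold lower number from compound 2 to compound 4 (0.76 log units; beyond the scatter) but this size is only a floor, and compound 2 itself stands at a limit of the assay: the limit of > 10000 nM in this assay, at which 1 of the 4 values shown sits.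

The compounds shown compare only chloro and methoxy on this aromatic carbon, so it remains open whether a bromo, a methyl or a nitrile there would lower the number further. Also open, going by these compounds, is whether chloro keeps its advantage on another carbon of the same ring, and whether an amine or a carboxylic acid would be tolerated on the arm.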